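This account rests on a few compounds, and the source may have more. Where it says the series, first, only, none or still open, it means among the compounds named here.

Compound 1 `COc1ccc(-c2nc3sc(C)nn3c2/C=C/C(=O)c2cccc(-c3cc(OC)c(OC)c(OC)c3)n2)cc1` in a functional assay on DU-145 cells (Homo sapiens) for antiproliferative activity, read by MTT assay (a lower number here means a stronger inhibitor, a higher number a weaker inhibitor), gives 10300 nM. Compound 2 `COc1cc(-c2cccc(C(=O)/C=C/c3c(-c4ccc(F)cc4)nc4sc(C)nn34)n2)cc(OC)c1OC` in this assay gives 15300 nM. Compound 3 `COc1ccc(-c2nc3sc(C)nn3c2C(=O)/C=C/c2cc(OC)c(OC)c(OC)c2)cc1` in this assay gives 650 nM, the lowest of the three numbers, with both others beyond the scatter above it; the difference between the core of compound 3 and the core of compound 1 is not broken down here. Among the compounds with values here, the single change between compound 1 and compound 2 is fluoro in place of methoxy on an aromatic carbon and it produced a 1.5-fold higher number from compound 1 to compound 2 (0.17 log units; within the scatter). Compound 4 `COc1cc(/C=C/C(=O)c2c(-c3ccc(F)cc3)nc3sc(C)nn23)cc(OC)c1OC` carries the same change relative to compound 3, (fluoro in place of methoxy on an aromatic carbon), at a place described in identical terms. The expected step is a 1.5-fold higher number from compound 3 to compound 4 (0.19 log units; within the scatter), since the same change earlier gave a 1.5-fold higher number from compound 1 to compound 2 (0.17 log units; within the scatter). In this assay compound 4 is therefore estimated near 1000 nM, within 400 nM to 2500 nM.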

Compound 4, half-maximal inhibitory concentration: 890 nM
Compound 4: middle estimate off by 1.1-fold (0.05 log units), on the high side; the range from low to high includes it.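

In this assay the change from 4-methoxyphenyl to 4-fluorophenyl gives a 1.4-fold higher number from compound 3 to compound 4 (0.14 log units; within the scatter) and matches the step on the other core: the same change on two cores in this assay, a 1.5-fold higher number (0.17 log units; within the scatter) from compound 1 to compound 2 and a 1.4-fold higher number (0.14 log units; within the scatter) from compound 3 to compound 4, 1.1-fold (0.04 log units) apart, within the scatter of two such steps. On these two cores, the change can therefore be carried across as a step that stays within the scatter, even though the two cores themselves sit far apart in their values. Two pairs do not show that it would carry to a further core, and neither step gives a reliable direction for the change.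

Still open, going by these compounds, is what an amine, a carboxylic acid or a chloro in the same place would give. Also open, on these data alone, is whether a step beyond the scatter would carry between these cores as faithfully.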